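Fluoro in Place of Methoxy: From Compound 2 to Compound 3

The source may report more compounds than this note shows. Statements on the series, on what has been measured and on what is new or still open speak of the compounds shown alone.

Two members of the shared core have been examined in a functional assay on MDA-MB-435 cells (Homo sapiens) for inhibition, read by sulforhodamine B assay, with a stated time of 48 h; on this read-out higher numbers stand for weaker inhibition of growth and lower numbers for stronger inhibition of growth. Compound 1 `COc1ccc(CNc2nc3cc(N)cc(N)c3nc2-c2ccccc2)cc1OC` gives 1950 nM in this assay. Compound 2 `COc1ccc(Sc2nc3cc(N)cc(N)c3nc2-c2ccccc2)cc1` is known in this assay only by a limit, < 100000 nM, and not by a number; this is the limit of < 100000 nM in this assay, at which 1 of the 2 values shown sits. Where compound 2 stands within that limit is therefore open, and no measured step connects it to compound 1.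

Compound 3 `Nc1cc(N)c2nc(-c3ccccc3)c(Sc3ccc(F)cc3)nc2c1` has not yet been measured. It differs from compound 2 by fluoro in place of methoxy on an aromatic carbon, leaving the rest of the structure untouched. Going by the values given here, with no measured step of this kind available, the step that the limit leaves unreadable from compound 2 to compound 3 is expected to be modest, and no direction beyond the scatter is expected. Compound 3 is accordingly estimated at 20000 nM in this assay, within a broad range from 2000 nM to 100000 nM.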

Compound 3, concentration for 50% growth inhibition: 16200 nM
Compound 3: the middle estimate sits 1.2-fold (0.09 log units) above what was measured; the measured number falls inside the stated range.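

No size can be read for the change from compound 2 to compound 3 in this assay, and compound 2 remains known only by a limit: the limit of < 100000 nM in this assay, at which 1 of the 3 values shown sits.

The compounds shown leave open whether fluoro in place of methoxy on an aromatic carbon changes growth inhibition at all, and in which direction.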